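An Iodine Substituent Weighed Against Two Chlorine Precedents

The source may report more compounds than this note shows. Statements on the series, on what has been measured and on what is new or still open speak of the compounds shown alone.

Compound 1 `OCc1cn(Cc2ccccc2)c2ccccc12` gives 30 nM in a functional assay on T29Kt1 cells (Homo sapiens) for cytotoxicity, read by sulforhodamine B assay, with a stated time of 3 days (a lower number here means a stronger inhibitor, a higher number a weaker inhibitor), the lowest of the three numbers in hand. Compound 3 `OCc1cn(Cc2ccc(Cl)cc2)c2ccccc12` gives 79 nM, a rise of a 2.6-fold higher number from compound 1 to compound 3 (0.42 log units; beyond the scatter), whereas compound 2 `OCc1cn(Cc2ccccc2Cl)c2ccccc12` gives 2510 nM, a rise of an 84-fold higher number from compound 1 to compound 2 (1.92 log units; beyond the scatter). Compound 4 `OCc1cn(Cc2cccc(I)c2)c2ccccc12` differs from compound 1 by iodo in place of hydrogen on an aromatic carbon. Among the compounds with values here, both measured steps put a chloro in place of hydrogen on an aromatic carbon of the same ring, yet neither places it where the iodo enters, and no step shows an iodo at all. Weighing a 2.6-fold higher number from compound 1 to compound 3 (0.42 log units; beyond the scatter) against an 84-fold higher number from compound 1 to compound 2 (1.92 log units; beyond the scatter), a moderate rise with wide uncertainty is expected for compound 4, a 5.0-fold higher number from compound 1 to compound 4 (0.70 log units; beyond the scatter). Compound 4 is therefore estimated at 150 nM, within 40 nM to 800 nM.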

Compound 4, half-maximal inhibitory concentration: 20 nM
Beside the measured number, compound 4's estimate is 7.5-fold (0.88 log units) above it, outside the stated range (below it).
By their numbers in this assay, from the lowest: compounds 4 and 1 (each within the scatter of the next); then compound 3; then compound 2.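

In this assay, iodo in place of hydrogen on an aromatic carbon, meta to a large group, gives a 1.5-fold lower number from compound 1 to compound 4 (0.18 log units; within the scatter) and so makes no change that can be told from the usual scatter. This position therefore accepts an iodo, whereas both chloro steps, made at other places on the same ring, lie beyond the scatter. Nothing measured here explains this result. The compounds shown leave open how a chloro would behave at this same position, and whether an amine, a carboxylic acid or a longer chain would be accepted there too.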